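The compounds below may be only part of what the source reports. "The series", "measured", "known", "first", "only" and "open" are said of these compounds alone.

Working notes on the pyrrolopyrimidine set, agonism in an assay on HEK293 cells for agonist activity at Toll-like receptor 8 (Homo sapiens), read by a luciferase reporter, with a stated time of 6 h; on this read-out lower numbers stand for an effect already at smaller amounts and higher numbers for an effect only at larger amounts of compound.

Compound 1 `CCCCNc1nc(N)nc2ccn(Cc3ccccc3)c12` carries a phenyl group on the saturated chain carbon bound to an aromatic nitrogen. In this assay compound 1 reaches only the limit > 25 uM. Compound 2 `CCCCNc1nc(N)nc2ccn(Cc3ccsc3)c12`, with thiophen-3-yl in that position, likewise sits at the limit > 25 uM in this assay. Among the measured compounds shown here, compound 3 `CCCCNc1nc(N)nc2ccn(Cc3nccs3)c12`, with 1,3-thiazol-2-yl in that position, gives 2.27 uM in this assay, the only actual number so far. The other two values are limits (the limit of > 25 uM in this assay, at which 2 of the 3 values shown sit). The step from compound 1 to compound 2 is a step that the two limits leave unreadable from compound 1 to compound 2. The steps of an at least 11-fold lower number from compound 1 to compound 3 (1.04 log units; beyond the scatter) and an at least 11-fold lower number from compound 2 to compound 3 (1.04 log units; beyond the scatter) are both large and beyond the scatter. Both start at a limit, so their true size is open.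

Compound 4 `CCCCNc1nc(N)nc2ccn(Cc3ccccn3)c12` is the next member; the change from compound 3 is pyridin-2-yl in place of 1,3-thiazol-2-yl on a saturated chain carbon bound to an aromatic nitrogen. For the measured compounds named here, the steps that bear on it are those into compound 3, which show that the five-membered ring with two hetero atoms is what separates the one active member from the two inactive ones. Pyridin-2-yl keeps one hetero atom and a larger ring; a modest loss is expected, with some chance of no number at all. The expected step is a 2.2-fold higher number from compound 3 to compound 4 (0.34 log units; beyond the scatter). Compound 4 is thus estimated at 5 uM, between 1.5 uM and 25 uM.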

Compound 4, minimum effective concentration: > 25 uM
Compound 4 gave a limit, no number; the forecaster's own chance of this, stated with the estimate: 25%; middle value at least 5.0-fold (0.69 log units) away from the limit.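

In this assay, among the compounds shown here, pyridin-2-yl in place of 1,3-thiazol-2-yl on a saturated chain carbon bound to an aromatic nitrogen gives an at least 11-fold higher number from compound 3 to compound 4 (1.04 log units; beyond the scatter), and this is the first step out of the one active member rather than into it. Until now, the only ring with a nitrogen in this position was the 1,3-thiazol-2-yl group of compound 3, while the phenyl of compound 1 and the thiophen-3-yl of compound 2 hold none; compound 4 shows that a ring nitrogen alone does not give a number here, so among these four compounds only the five-membered aromatic ring with 2 hetero atoms of compound 3 does. Compound 4 gives a limit and not a number, so its steps from compound 1 and from compound 2 cannot be read, and these three compounds cannot be ordered: the limit of > 25 uM in this assay, at which 3 of the 4 values shown sit.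

The compounds shown do not separate the ring size from the sulfur or from the second hetero atom. On these data alone, a 1,3-oxazol-2-yl or a pyrimidin-2-yl group in the same place would bear on that question, and the true size of the step into compound 4 also stays open.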